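An Unmeasured Replacement for the 4-Chlorophenyl Group

The source may report more compounds than this note shows. Statements on the series, on what has been measured and on what is new or still open speak of the compounds shown alone.

In a functional assay on SW-620 cells (Homo sapiens) for inhibition, read by MTT assay, with a stated time of 72 h (on this read-out lower numbers stand for stronger inhibition and higher numbers for weaker inhibition), compound 1 `COc1cc(NC(C)CCCNC(=O)Nc2cccc(O)c2)c2ncccc2c1` gives 27000 nM and compound 2 `COc1cc(NC(C)CCCNC(=O)Nc2ccc(Cl)cc2)c2ncccc2c1` gives 28000 nM. Going by the values given here, the two stand level: the only measured step, a 1.0-fold higher number from compound 1 to compound 2 (0.02 log units; within the scatter), lies within the scatter. Compound 3 `COc1cc(NC(C)CCCNC(=O)NNC(=O)Nc2cccc(Cl)c2)c2ncccc2c1` departs from compound 2 as follows: ((3-chlorophenyl)carbamoyl)amino in place of 4-chlorophenyl on an amide-type nitrogen. That one measured step is a weak guide, since it covers only 4-chlorophenyl in place of 3-hydroxyphenyl on an amide-type nitrogen. Among the compounds with values here, no measured step covers the entering ((3-chlorophenyl)carbamoyl)amino, so the data give no direction for the change. No step beyond the scatter is therefore expected in this assay, though with wide uncertainty. The expected step is a 1.6-fold lower number from compound 2 to compound 3 (0.19 log units; within the scatter). Compound 3 is estimated at 18000 nM, with an expected range from 6000 nM to 45000 nM.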

Compound 3, half-maximal inhibitory concentration: 25000 nM
Beside the measured number, compound 3's estimate is 1.4-fold (0.14 log units) below it; the range from low to high includes it.
By their numbers in this assay, from the lowest: compounds 3, 1 and 2 (each within the scatter of the next).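

In this assay, the ((3-chlorophenyl)carbamoyl)amino group in place of 4-chlorophenyl gives a 1.1-fold lower number from compound 2 to compound 3 (0.05 log units; within the scatter), and in place of 3-hydroxyphenyl it gives a 1.1-fold lower number from compound 1 to compound 3 (0.03 log units; within the scatter); both steps lie within the scatter. The position on the amide-type nitrogen therefore accepts a group that differs from the two earlier ones in its count of heavy atoms and hydrogen-bond donors, without a change that the three compounds can resolve. No measurement at hand bears on why the three stand level.

The compounds shown do not separate the entering carbamoyl-amino link from the move from 4-chlorophenyl to 3-chlorophenyl. Going by these compounds, all three also carry an aromatic ring of carbon at this position, so it remains open whether a primary amine, a carboxylic acid or a plain alkyl chain there would give a step beyond the scatter.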